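Trimming Isopropyl to Ethyl on the Shared Core

The source may hold more compounds than are shown below. What is called first, only, known or untested is meant among the compounds shown, and "the series" means these compounds.

Compound 1 `CC(C)c1ccccc1-c1cc2cc(CCC(=O)O)ccc2[nH]1` and compound 2 `COc1ccc(-c2cc3cc(CCC(=O)O)ccc3[nH]2)cc1` share one core and differ in the aryl group attached to it. In a functional assay on CHO cells for agonist activity at Free fatty acid receptor 1 (Homo sapiens), read by a luciferase reporter, with a stated time of 24 h (a higher number here means that more compound is needed for the effect, a lower number that less compound is needed), compound 1 gives only a limit of the assay, > 25 nM. Compound 2 likewise gives only a limit in this assay, > 25 nM. Both values therefore sit at the limit of > 25 nM in this assay, at which 2 of the 2 values shown sit, and no number separates the two compounds. Compound 3 `CCc1ccccc1-c1cc2cc(CCC(=O)O)ccc2[nH]1` has not yet been measured in this assay. It differs from compound 1 by hydrogen in place of methyl on a saturated chain carbon bound to an aromatic carbon and a saturated chain carbon; cut one bond further out, the same difference reads isopropyl to ethyl. Going by the values given here, no step between measured compounds is available, so the size of this change cannot be read from the data. One expects compound 3 to stay near the limit, with a step that the limit leaves unreadable from compound 1 to compound 3 that is not expected to go beyond the usual scatter. The estimate for compound 3 in this assay is 60 nM, within a range from 20 nM to 300 nM.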

Compound 3, half-maximal effective concentration: 1800 nM
Estimate against measurement, compound 3: 30-fold (1.48 log units) below; the whole stated range lies below it.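

Going by these compounds alone, compound 1 gives only a limit in this assay, so no step from compound 1 to compound 3 can be read: the limit of > 25 nM in this assay, at which 2 of the 3 values shown sit. The compounds shown leave open how far, and in which direction, the change from isopropyl to ethyl moves the half-maximal effective concentration.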